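A few compounds are considered here, and "the series" means these few. Any claim that something is new, unique, unknown or untested is made for them only; others in the source may bear on it.

Working notes on the series. Compound 1 `OC[C@@H](O)[C@H]1O[C@@H](n2cnc3c(Cl)nc(Cl)nc32)[C@H](O)[C@@H]1O` gives 47100 nM in a functional assay on HeLa cells (Homo sapiens), read by colorimetric assay, with a stated time of 48 h; a higher number here means a weaker inhibitor, a lower number a stronger inhibitor. Compound 2 `Nc1nc(Cl)nc2c1ncn2[C@@H]1O[C@H]([C@H](O)CO)[C@@H](O)[C@H]1O` is the same core with amino in place of chloro on an aromatic carbon; in this assay compound 2 returns only > 100000 nM, which is a limit of the assay. The step of an at least 2.1-fold higher number from compound 1 to compound 2 (0.32 log units; beyond the scatter) is thus known only as a lower bound, set by the limit of > 100000 nM in this assay, at which 1 of the 3 values shown sits. Compound 3 `CC(=O)OC[C@@H](OC(C)=O)[C@H]1O[C@@H](n2cnc3c(Cl)nc(Cl)nc32)[C@H](OC(C)=O)[C@@H]1OC(C)=O` gives 24200 nM in this assay; against compound 1 the difference between the two cores is not broken down here, and the two values lie within the scatter of each other. Compound 4 `CC(=O)OC[C@@H](OC(C)=O)[C@H]1O[C@@H](n2cnc3c(N)nc(Cl)nc32)[C@H](OC(C)=O)[C@@H]1OC(C)=O` carries the same change on the core of compound 3: amino in place of chloro on an aromatic carbon. Given an at least 2.1-fold higher number from compound 1 to compound 2 (0.32 log units; beyond the scatter), compound 4 is expected at 90000 nM in this assay, plausibly between 40000 nM and 200000 nM, meaning an estimated step of a 3.7-fold higher number from compound 3 to compound 4 (0.57 log units; beyond the scatter), with a fair chance that only a limit is returned.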

Compound 4, half-maximal inhibitory concentration: > 100000 nM
Compound 4 ended at the assay's limit; the forecaster's own chance of this, stated with the estimate: 45%; middle value at least 1.1-fold (0.04 log units) away from the limit.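

Amino in place of chloro on an aromatic carbon gives an at least 4.1-fold higher number from compound 3 to compound 4 (0.61 log units; beyond the scatter) in this assay, so the number rises on both cores shown. Set side by side, the two steps read: the same change on two cores in this assay, an at least 2.1-fold higher number (0.32 log units; beyond the scatter) from compound 1 to compound 2 and an at least 4.1-fold higher number (0.61 log units; beyond the scatter) from compound 3 to compound 4; the limit leaves it open whether they differ. Both are lower bounds, so neither the true size of the change on either core nor any dependence on the core is shown, and the data reach the top of the readable range: the limit of > 100000 nM in this assay, at which 2 of the 4 values shown sit.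

The compounds shown leave open how a methylamino or methoxy group in place of the same chloro would read in this assay. Also open, from the compounds shown here alone, is what replacing the remaining chloro group would do on either core.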